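Swapping the aryl group on a fused bicyclic cytotoxic scaffold

A few compounds are considered here, and "the series" means these few. Any claim that something is new, unique, unknown or untested is made for them only; others in the source may bear on it.

Measured so far:
compound 1 `CCOC(=O)CC1C(C(=O)OCC)=C(N)Oc2ccc(-c3cc(F)cc(F)c3)cc21` gives 35900 nM
compound 2 `CCOC(=O)CC1C(C(=O)OCC)=C(N)Oc2ccc(-c3ccccn3)cc21` gives 76900 nM

Both values come from a functional assay on HL-60 cells (Homo sapiens) for cytotoxicity, read by CellTiter-Blue, with a stated time of 48 h; a higher number here means a weaker inhibitor, a lower number a stronger inhibitor. Compound 2 gives the highest of the two numbers, so it is the weaker inhibitor of the pair: a 2.1-fold higher number from compound 1 to compound 2 (0.33 log units; beyond the scatter).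

Compound 3 `CCOC(=O)CC1C(C(=O)OCC)=C(N)Oc2ccc(-c3ccc(N)cc3)cc21` is the next step from compound 2, and it changes the group on the same aromatic carbon: 4-aminophenyl in place of pyridin-2-yl on an aromatic carbon. Among the measured compounds shown here, no measured step involves 4-aminophenyl, so the only guide is the step between compound 1 and compound 2, where a ring of carbon only carrying two fluorines gave the lower number and the pyridin-2-yl ring gave the higher one. Returning to a ring of carbon only might therefore move the number back toward compound 1, but the amino group is new and untested. A modest lowering is expected, a 1.8-fold lower number from compound 2 to compound 3 (0.26 log units; within the scatter), and compound 3 is estimated at 42000 nM, ranging from 15000 nM to 115000 nM.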

Compound 3, half-maximal inhibitory concentration: 22300 nM
Compound 3: the middle estimate sits 1.9-fold (0.27 log units) above what was measured; the range from low to high includes it.
By their numbers in this assay, from the lowest: compounds 3 and 1 (each within the scatter of the next); then compound 2.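

At this aromatic carbon, 4-aminophenyl in place of pyridin-2-yl gives a 3.4-fold lower number from compound 2 to compound 3 (0.54 log units; beyond the scatter) in this assay and leaves compound 2 alone at the high end, with the two rings of carbon only on the lower side. Putting 4-aminophenyl in place of 3,5-difluorophenyl gives a 1.6-fold lower number from compound 1 to compound 3 (0.21 log units; within the scatter) and so shows no real change, even though the two fluorines are gone and an amino group has come in. Nothing at hand explains why the pyridin-2-yl ring stands apart from the other two.

As far as these compounds go, it remains open whether a plain phenyl ring, or a phenyl ring carrying a carboxylic acid or a methoxy group, would sit with these two rings of carbon only. A pyridin-4-yl group would show whether the place of the ring nitrogen matters, which the pyridin-2-yl ring alone cannot tell.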